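Swapping a Methyl for Chlorine on the Aryl Alkyne

The compounds below may be only part of what the source reports. "The series", "measured", "known", "first", "only" and "open" are said of these compounds alone.

Measured so far in a functional assay on HEK293 cells for positive allosteric modulation of metabotropic glutamate receptor 5 (Homo sapiens), read by FLIPR and calcium flux; a lower number here means that less compound is needed, a higher number that more compound is needed for the effect:
Compound 1, `CC(C)NC(=O)c1ccc(C#Cc2ccccc2)nc1`: 62 nM
Compound 2, `CN1CCc2nc(C#Cc3cccnc3)ccc2C1=O`: "not active" (no number reported)
Compound 3, `Cc1cccc(C#Cc2ccc3c(n2)CCN(C2CCCC2)C3=O)c1`: 7.5 nM

Three compounds carry the same triple-bonded link between two aromatic rings, and only two of them give a number in this assay. Compound 2 is reported as not active, with no number attached. Of the two that do give a number, compound 3 has the lower one, and the number for compound 1 lies clearly higher, beyond the usual scatter of repeated measurements. Compound 3 is therefore the most potent of the compounds that have a number here.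

Among the measured compounds shown here, the next compound, compound 4, `O=C1c2ccc(C#Cc3ccc(Cl)cc3)nc2CCN1C1CCCC1`, keeps the whole core of compound 3 and changes only one ring at the end of the alkyne: 4-chlorophenyl in place of 3-methylphenyl on a triple-bonded carbon. The two groups that leave and enter are the same size, and neither carries a hydrogen-bond donor or acceptor. For the measured compounds named here, no step between measured compounds tells how such a swap plays out, so the expectation rests on compound 3 alone. A step of about the size of the scatter, in either direction, is expected from compound 3 to compound 4: a 1.3-fold higher number from compound 3 to compound 4 (0.12 log units; within the scatter). Compound 4 is accordingly estimated at 10 nM, within a range from 3 nM to 35 nM.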

Compound 4, half-maximal effective concentration: 979 nM
Beside the measured number, compound 4's estimate is 98-fold (1.99 log units) below it; the whole stated range lies below it.
By their numbers in this assay, from the lowest: compound 3; then compound 1; then compound 4.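

In this assay, putting 4-chlorophenyl in place of 3-methylphenyl on the triple-bonded carbon gives a 130-fold higher number from compound 3 to compound 4 (2.12 log units; beyond the scatter), so the potency of this series depends strongly on what sits on the far end of the alkyne. The two groups have the same number of heavy atoms and the same counts of hydrogen-bond donors and acceptors, and each is one six-membered aromatic ring of carbon only, yet their compounds give very different numbers, so these simple counts do not predict the outcome at this position. Nothing measured here gives a reason for the drop in potency.

This swap changes two things at once, the group on the ring and where it sits, and the compounds shown leave open which of the two matters, a question that 3-chlorophenyl or 4-methylphenyl on the same core could answer. They also leave open how other rings at this place would behave, such as unsubstituted phenyl or a phenyl ring carrying a methoxy group or a nitrile.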